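This account rests on a few compounds, and the source may have more. Where it says the series, first, only, none or still open, it means among the compounds named here.

Compound 3 `COC(=O)/C(=C/c1ccccc1)CN1C(=O)[C@@H](OC)[C@H]1c1ccc(OC)cc1` is a small amide ring that carries a methoxy group and a 4-methoxyphenyl on its saturated carbons. For the measured compounds named here, in a functional assay on MCF7 cells (Homo sapiens) for antiproliferative activity, read by MTT assay, with a stated time of 48 h (a higher number here means a weaker inhibitor, a lower number a stronger inhibitor), compound 3 gives 11600 nM, the lowest of the three numbers measured so far. Its neighbours are compound 1 `COC(=O)/C(=C/c1ccccc1)CN1C(=O)[C@@H](OC)[C@H]1c1cccc(Cl)c1`, which gives 25100 nM, and compound 2 `CCOC(=O)/C(=C/c1ccccc1)CN1C(=O)[C@@H](OC)[C@H]1c1cccc([N+](=O)[O-])c1`, which gives 19900 nM; the gap to compound 2 lies within the usual scatter, the gap to compound 1 beyond it.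

Compound 4 `COC(=O)/C(=C/c1ccccc1)CN1C(=O)[C@@H](OC)[C@H]1c1cccc([N+](=O)[O-])c1` differs from compound 3 in one place: 3-nitrophenyl in place of 4-methoxyphenyl on a saturated ring carbon. Going by the values given here, the only measured step touching this position is a 2.2-fold lower number from compound 1 to compound 3 (0.34 log units; beyond the scatter), a modest shift in the other direction. Compound 2 also carries a 3-nitrophenyl, though with an ethyl ester, and its number sits close to that of compound 3. Together these suggest that in this assay the change to compound 4 brings at most a small rise in the number, and the estimated step is a 1.7-fold higher number from compound 3 to compound 4 (0.24 log units; within the scatter). Compound 4 is therefore expected to give about 20000 nM, within a range of 9000 nM to 45000 nM.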

Compound 4, half-maximal inhibitory concentration: 15000 nM
Compound 4: middle estimate off by 1.3-fold (0.12 log units), on the high side, within the range that was stated.
By their numbers in this assay, from the lowest: compounds 3, 4, 2 and 1 (each within the scatter of the next, the first and the last beyond it).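

In this assay, 3-nitrophenyl in place of 4-methoxyphenyl on this saturated ring carbon gives a 1.3-fold higher number from compound 3 to compound 4 (0.11 log units; within the scatter) and so the two groups cannot be told apart here. Nitro in place of chloro on the aromatic carbon gives a 1.7-fold lower number from compound 1 to compound 4 (0.22 log units; within the scatter) and the ester offers a first reading of a second place, where the methyl ester in place of the ethyl ester gives a 1.3-fold lower number from compound 2 to compound 4 (0.12 log units; within the scatter) so both of these changes also stay within the scatter. Nothing available explains why these steps are so small.

From the compounds shown here alone, all of these groups leave the number in one narrow region, so it remains open how far this position can shift it. An amine on the phenyl ring, or a carboxylic acid in place of the ester, might show whether either place can produce a larger step.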